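The compounds below may be only part of what the source reports. "The series", "measured", "known", "first", "only" and "open" are said of these compounds alone.

Measured in an ADME assay on microsomes from liver (Mus musculus) for metabolic stability, with a stated time of 10 min; a lower number here means that less of the compound is left, a higher number that more of the compound is left:
- Compound 1 `Nc1c(C(=O)N[C@@H]2CCc3cc(OCc4ccccc4)ccc32)[nH]c(=O)[nH]c1=O`: 85%
- Compound 2 `O=C(N[C@H]1CC[C@@H](c2ccccc2)CC1)c1[nH]c(=O)[nH]c(=O)c1O`: 100%
- Compound 3 `CC(C)Cn1c(=O)[nH]c(C(=O)N[C@H]2CC[C@@H](c3ccccc3)CC2)c(O)c1=O`: 100%

Beside compound 2, compound 3 stands level at 100%. Compound 1 gives 85%, which falls short of compound 3 by more than the usual scatter. Compound 4 `O=C(N[C@H]1CC[C@@H](c2ccccc2)CC1)c1[nH]c(=O)n(Cc2ccccc2)c(=O)c1O` carries phenyl in place of isopropyl on a saturated chain carbon bound to an aromatic nitrogen, which also reads as isobutyl to benzyl. Among the measured compounds shown here, the one measured step bearing on this, no change at the digits printed from compound 2 to compound 3 (within the scatter), put isobutyl in place of hydrogen on an aromatic nitrogen and stayed within the scatter. For the measured compounds named here, no measured compound carries benzyl at that place, so the evidence is thin, and no step beyond the scatter is expected in this assay. The estimated step, a number 7 percentage points lower from compound 3 to compound 4 (within the scatter), is expected to stay within the scatter. For compound 4 the expected value is 93%, with an estimated range of 75% to 100%.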

Compound 4, percent of the compound remaining: 0.78%
Compound 4: the middle estimate sits 92.2 percentage points above what was measured; measured number outside the range, below it.
By their numbers in this assay, from the lowest: compound 4; then compound 1; then compounds 2 and 3 (each within the scatter of the next).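

In this assay the substituent on the aromatic nitrogen proved able to decide the outcome: phenyl in place of isopropyl on the saturated chain carbon brought a number 99.2 percentage points lower from compound 3 to compound 4 (beyond the scatter) and benzyl in place of hydrogen brought a number 99.2 percentage points lower from compound 2 to compound 4 (beyond the scatter) in the same series. The earlier step, no change at the digits printed from compound 2 to compound 3 (within the scatter) with isobutyl, gave no sign that this place could matter so much. Nothing measured here bears on why the benzyl group behaves so differently from isobutyl.

The compounds shown leave open whether a longer chain ending in phenyl would behave like benzyl. They also leave open whether a pyridine ring in place of the phenyl would do so.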